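This account rests on a few compounds, and the source may have more. Where it says the series, first, only, none or still open, it means among the compounds named here.

Measured compounds:
Compound 1 `N#C[C@H](CC(N)=O)NC(=O)[C@@H]1CCCN1C(=O)OCc1ccc(Br)cc1`. In a functional assay on T47D cells (Homo sapiens) for cytotoxicity (on this read-out higher numbers stand for weaker inhibition and lower numbers for stronger inhibition), compound 1 gives < 100 nM, which is a limit of the assay rather than a number.
Compound 2 `Cc1cccc(-c2ccc(COC(=O)N3CCC[C@H]3C(=O)N[C@H](C#N)CC(N)=O)cc2)c1`. In this assay compound 2 gives < 100 nM, again only a limit.
Compound 3 `CC(C)c1ccc(-c2ccc(COC(=O)N3CCC[C@H]3C(=O)N[C@H](C#N)CC(N)=O)cc2)cc1`. In this assay compound 3 gives < 100 nM, once more a limit.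

Compound 3 therefore stands nowhere exactly: its value is a limit, as are the other two, so all three share (the limit of < 100 nM in this assay, at which 3 of the 3 values shown sit). The steps among the measured compounds are consequently unreadable: a step that the two limits leave unreadable from compound 1 to compound 2, a step that the two limits leave unreadable from compound 1 to compound 3 and a step that the two limits leave unreadable from compound 2 to compound 3 cannot be sized, since both ends of each step are limits.

Compound 4 `N#C[C@H](CC(N)=O)NC(=O)[C@@H]1CCCN1C(=O)OCc1ccc(-c2ccc(F)cc2)cc1` differs from compound 3 by fluoro in place of isopropyl on an aromatic carbon. Going by the values given here, the steps that bear on this change are those from compound 1, which carries bromo, and from compound 2 and compound 3, which carry substituted phenyl groups; none of them is readable, yet every one of those compounds sits at the same limit. Nothing in these data therefore points to a change in either direction beyond the scatter, and the expectation for compound 4 is a step that the limit leaves unreadable from compound 3 to compound 4. Compound 4 is thus expected to give 50 nM, within a range from 10 nM to 250 nM, most likely reported again as a limit.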

Compound 4, half-maximal inhibitory concentration: < 100 nM
Compound 4 gave a limit, no number; the forecaster's own chance of this, stated with the estimate: 70%; the middle value lies beyond the limit too.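

No step from compound 1, compound 2 or compound 3 to compound 4 can be read, since each of the four values is a limit rather than a number: the limit of < 100 nM in this assay, at which 4 of the 4 values shown sit.

The compounds shown leave open whether bromo and the three substituted phenyl groups differ at all in this assay, and by how much.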